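Swapping 4-methoxybenzyl for 2-cyanobenzyl on a shared core

This account rests on a few compounds, and the source may have more. Where it says the series, first, only, none or still open, it means among the compounds named here.

- Compound 1 `COC(=O)c1ccc(NCc2cncn2Cc2cccc(Br)c2)cc1-c1ccccc1`: > 10000 nM (a limit, not a number)
- Compound 2 `COC(=O)c1ccc(NCc2cncn2Cc2ccccc2Cl)cc1-c1ccccc1`: 10000 nM
- Compound 3 `COC(=O)c1ccc(NCc2cncn2Cc2ccc(OC)cc2)cc1-c1ccccc1`: "not determined" (no result reported)

These compounds were tested in a toxicity assay on NIH3T3 cells (Mus musculus) for cytotoxicity, read by resazurin assay; a lower number here means that less compound is needed, a higher number that more compound is needed for the effect. Compound 1 gives > 10000 nM, which is a limit of the assay and not a number. Compound 2 gives 10000 nM. For compound 3 the result reads "not determined" (no result reported), so the starting point for the next step has no number.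

That step leads to compound 4 `COC(=O)c1ccc(NCc2cncn2Cc2ccccc2C#N)cc1-c1ccccc1` through one swap: 2-cyanophenyl in place of 4-methoxyphenyl on a saturated chain carbon bound to an aromatic nitrogen. Here 2-cyanophenyl takes the place of 4-methoxyphenyl on a saturated chain carbon bound to an aromatic nitrogen. One measured step involves a change at this same place: a number no higher from compound 1 to compound 2 (the limit leaves the size open). From the compounds shown here alone, one end of it is a limit and its size stays open. Among the measured compounds shown here, with compound 2 at 10000 nM as the only real number, compound 4 is expected to lie in the same region, with no step beyond the usual scatter. For compound 4 the expected value is 10000 nM, with an estimated range from 4000 nM to 25000 nM.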

Compound 4, half-maximal effective concentration: 25000 nM
For compound 4 the middle estimate is 2.5-fold (0.40 log units) below the measured one; measured number inside the range.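

In this assay, among the compounds shown here, the shared core now gives a first readable step among the ortho-free wording of the names, 2-chlorophenyl and 2-cyanophenyl: cyano in place of chloro produces a 2.5-fold higher number from compound 2 to compound 4 (0.40 log units; beyond the scatter), so more compound is needed for the cytotoxic effect. For the compounds shown here, this small step lies beyond the usual scatter, which the earlier compounds could not show, since they offered no step of readable size. The step from compound 1 to compound 4 cannot be read, because compound 1 stands at a limit of the assay and not at a number: the limit of > 10000 nM in this assay, at which 1 of the 4 values shown sits.

Compound 3 has no number, so the swap from 4-methoxybenzyl to 2-cyanobenzyl itself has no size, and one readable step sets no trend. From the compounds shown here alone, how a benzyl group carrying an amine or a carboxylic acid would read remains open.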